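Compound 3 to compound 4 at the limit of the assay

The source may report more compounds than this note shows. Statements on the series, on what has been measured and on what is new or still open speak of the compounds shown alone.

Measured in a functional assay on NALM-6 cells (Homo sapiens) for cytotoxicity, with a stated time of 72 h (a lower number here means that less compound is needed, a higher number that more compound is needed for the effect), with each value a limit and not a number:
compound 1 (`C=C[C@@](C)(/C=C/c1ccc(OS(=O)(=O)C(F)(F)F)cc1)CCC=C(C)C`) gives > 43400 nM
compound 2 (`C=C[C@@](C)(/C=C/c1ccc(Nc2ccccc2)cc1)CCC=C(C)C`) gives > 43400 nM
compound 3 (`C=C[C@@](C)(/C=C/c1ccc(Nc2ccc(F)c(F)c2)cc1)CCC=C(C)C`) gives > 43400 nM

Compound 3 gives > 43400 nM in this assay, and this is a limit, so it has no readable rank. All three measured compounds share that position (the limit of > 43400 nM in this assay, at which 3 of the 3 values shown sit), and none can be placed ahead of another.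

Compound 4 (`C=C[C@@](C)(/C=C/c1ccc(Nc2ccc(Cl)c(Cl)c2)cc1)CCC=C(C)C`) carries 3,4-dichlorophenyl in place of 3,4-difluorophenyl on a nitrogen on an aromatic ring. The closest measured change is a step that the two limits leave unreadable from compound 2 to compound 3, which put 3,4-difluorophenyl in place of phenyl on that nitrogen. Two further changes at the same part of the molecule are a step that the two limits leave unreadable from compound 1 to compound 2 and a step that the two limits leave unreadable from compound 1 to compound 3, and neither gives a size. The data therefore offer no measured size to carry over, and no step beyond the scatter is expected in this assay. The expected change is an at least 1.0-fold lower number from compound 3 to compound 4 (0.03 log units; that floor lies within the scatter), and this remains a cautious estimate resting only on limits. For compound 4 the estimated value is 40000 nM, with an expected range from 15000 nM to 60000 nM.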

Compound 4, half-maximal effective concentration: > 43400 nM
Compound 4 gave a limit, no number (the forecaster's own chance of this, stated with the estimate: 75%); middle value at least 1.0-fold (0.03 log units) from the limit.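

Compound 4 sits at a limit in this assay, as do compound 1, compound 2 and compound 3, so no step from any of them to compound 4 can be read: the limit of > 43400 nM in this assay, at which 4 of the 4 values shown sit.

The compounds shown leave open whether any of these groups on the shared core changes the cytotoxicity at all, and by how much.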